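This account rests on a few compounds, and the source may have more. Where it says the series, first, only, none or still open, it means among the compounds named here.

Working notes on the series. In an ADME assay on KB cells (Homo sapiens) for cytotoxicity, read by MTT assay, with a stated time of 72 h (on this read-out lower numbers stand for stronger inhibition and higher numbers for weaker inhibition), compound 1 `COc1cc(C2=C(c3ccc(SC)cc3)CC(O[SiH2]C(C)(C)C)C2=O)cc(OC)c1OC` gives 10 ug/mL and compound 2 `CC(=O)OC1C/C(=N/O)C(c2ccccc2)=C1c1ccccc1` gives 9 ug/mL. Going by the values given here, these two values lie within the scatter of each other, so compound 2 stands level with compound 1 on the numbers so far. Among the compounds with values here, the two compounds do not differ in one place, so no measured step is available for comparison.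

The next entry is compound 3 `O/N=C1/CC(O)C(c2ccccc2)=C1c1ccccc1`, reached from compound 2 by one change: hydrogen in place of acetyl on an oxygen on a saturated carbon. This is hydrogen in place of acetyl on an oxygen on a saturated carbon, or acetoxy to hydroxy.

Within the data shown here, no measured pair shows this change in this assay, so the expectation rests on the value of compound 2 at 9 ug/mL and remains loose. A small move toward a higher number, meaning weaker inhibition, is expected, with no shift clearly beyond the scatter. The expected change is a 1.3-fold higher number from compound 2 to compound 3 (0.12 log units; within the scatter). For compound 3 the estimated value is 12 ug/mL, with an expected range from 5 ug/mL to 30 ug/mL.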

Compound 3, half-maximal inhibitory concentration: > 100 ug/mL
Compound 3 was reported as a limit (the forecaster's own chance of this, stated with the estimate: 10%); middle value at least 8.3-fold (0.92 log units) from the limit.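

Going by these compounds alone, at this position, on an oxygen on a saturated carbon whose other neighbour is a saturated ring carbon, the change from acetoxy to hydroxy gives the first measured step: in this assay it runs as an at least 11-fold higher number from compound 2 to compound 3 (1.04 log units; beyond the scatter) and points to weaker inhibition, so the acetyl on this oxygen matters to the read-out in this pair. Compound 3 is given in this assay only as the limit > 100 ug/mL and not as a number. The step therefore marks a minimum size, and its full size cannot be read from this pair: the limit of > 100 ug/mL in this assay, at which 1 of the 3 values shown sits.

Whether the acetyl group itself is needed, or whether another group on the same oxygen would serve as well, stays open, since a methyl ether or a longer acyl chain such as propionyl or benzoyl does not stand among the compounds shown. From the compounds shown here alone, the step also rests on this one pair, so whether the same exchange acts alike on the core of compound 1 remains unknown.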